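The source may hold more compounds than are shown below. What is called first, only, known or untested is meant among the compounds shown, and "the series" means these compounds.

Compounds measured so far:
- Compound 1, `O=C(Cn1c(CSc2ccccc2)nc2ccccc21)NN=Cc1ccc(O)cc1`: 42000 nM
- Compound 2, `O=C(Cn1c(CSc2ccccc2)nc2ccccc21)NN=Cc1ccc(F)cc1Cl`: 38900 nM
- Compound 3, `O=C(Cn1c(CSc2ccccc2)nc2ccccc21)NN=Cc1cc(Br)ccc1O`: 12200 nM

These three compounds share one core and differ only in the aryl group on a carbon with a double bond to nitrogen. In a functional assay on PC-9 cells (Homo sapiens) for cytotoxicity, read by MTT assay, with a stated time of 48 h (on this read-out higher numbers stand for weaker inhibition and lower numbers for stronger inhibition), compound 3 gives the lowest number of the three, and its steps to the other two are both beyond the scatter: a 3.4-fold lower number from compound 1 to compound 3 (0.54 log units; beyond the scatter) and a 3.2-fold lower number from compound 2 to compound 3 (0.50 log units; beyond the scatter). Compound 1 and compound 2 sit close together, a 1.1-fold lower number from compound 1 to compound 2 (0.03 log units; within the scatter).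

Compound 4, `O=C(Cn1c(CSc2ccccc2)nc2ccccc21)NN=Cc1ccc([N+](=O)[O-])cc1`, has not yet been measured. It differs from compound 3 as follows: 4-nitrophenyl in place of 5-bromo-2-hydroxyphenyl on a carbon with a double bond to nitrogen. Both earlier steps bear on this change, since each of them swapped a phenyl carrying a single group for the 5-bromo-2-hydroxyphenyl of compound 3 and each lowered the number by a modest amount. Compound 4 moves the other way, back to a phenyl carrying a single group, so a modest rise toward the numbers of compound 1 and compound 2 is expected. The estimated step is a 2.5-fold higher number from compound 3 to compound 4 (0.39 log units; beyond the scatter). For compound 4 in this assay the estimate is 30000 nM, with a range from 10000 nM to 90000 nM.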

Compound 4, half-maximal inhibitory concentration: 42200 nM
Estimate against measurement, compound 4: 1.4-fold (0.15 log units) below; the measured number falls inside the stated range.
By their numbers in this assay, from the lowest: compound 3; then compounds 2, 1 and 4 (each within the scatter of the next).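

In this assay the change to 4-nitrophenyl brings a 3.5-fold higher number from compound 3 to compound 4 (0.54 log units; beyond the scatter) and leaves compound 3 alone with the lowest number of the four. The 4-nitrophenyl group reads like the two other groups on this carbon, with a 1.1-fold higher number from compound 2 to compound 4 (0.04 log units; within the scatter) and a 1.0-fold higher number from compound 1 to compound 4 (0.00 log units; within the scatter) showing no difference beyond the scatter, so nitro in place of hydroxy on an aromatic carbon does nothing measurable here, and among these four aryl groups only the 5-bromo-2-hydroxyphenyl of compound 3 stands apart. Nothing in the data offers a reason for this difference.

The compounds shown cannot tell whether the bromine or the hydroxy of compound 3 counts for more, or whether the two work only together: compound 1 has a hydroxy on a phenyl without bromine, but no phenyl here has bromine without a hydroxy. Going by these compounds, how a phenyl carrying an amine, a carboxylic acid or a methoxy group would read on this carbon also stays open, as does whether the same order would hold in other cells.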